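The source may report more compounds than this note shows. Statements on the series, on what has been measured and on what is new or still open speak of the compounds shown alone.

Compound 1 `CC(C)(C)n1cc2c(n1)C(=O)CC1(CCN(C(=O)c3cc(-c4ccccc4Cl)nc4ccccc34)CC1)O2`: 2180 nM
Compound 2 `CC(C)(C)n1cc2c(n1)C(=O)CC1(CCN(C(=O)c3cc(-c4ccc(N)cc4)nc4ccccc34)CC1)O2`: 970 nM
Compound 3 `CC(C)(C)n1cc2c(n1)C(=O)CC1(CCN(C(=O)c3cc(-c4ccccn4)nc4ccccc34)CC1)O2`: 7720 nM

In a functional assay on A549 cells (Homo sapiens) for inhibition, read by MTT assay, with a stated time of 72 h (a higher number here means a weaker inhibitor, a lower number a stronger inhibitor), compound 3 gives the highest number of the three, 7720 nM, which makes it the weakest inhibitor here. Compound 4 `CC(C)(C)n1cc2c(n1)C(=O)CC1(CCN(C(=O)c3cc(N4CCNCC4)nc4ccccc34)CC1)O2` is not yet measured. It carries piperazin-1-yl in place of pyridin-2-yl on an aromatic carbon, next to the ring nitrogen: piperazin-1-yl in place of pyridin-2-yl on an aromatic carbon. Three swaps at this same carbon bear on it: a 2.2-fold lower number from compound 1 to compound 2 (0.35 log units; beyond the scatter), a 3.5-fold higher number from compound 1 to compound 3 (0.55 log units; beyond the scatter) and an 8.0-fold higher number from compound 2 to compound 3 (0.90 log units; beyond the scatter). None of them brings in a non-aromatic ring, so they guide this change only loosely. Compound 3 already holds the top value, 7720 nM, so a modest step to a lower number in this assay is expected. The expected change is a 2.6-fold lower number from compound 3 to compound 4 (0.41 log units; beyond the scatter). For compound 4 the estimated value is 3000 nM, with an expected range from 800 nM to 11000 nM.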

Compound 4, half-maximal inhibitory concentration: > 10000 nM
Compound 4: only a limit was reported; the forecaster's own chance of this, stated with the estimate: 5%; middle value at least 3.3-fold (0.52 log units) away from the limit.
By their numbers in this assay, from the lowest: compound 2; then compound 1; then compound 3. At a limit, above all of these: compound 4.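

In this assay compound 4 gives > 10000 nM, which is a limit of the assay and not a number. Piperazin-1-yl is the only non-aromatic ring at this carbon among the compounds shown, and against the two substituted phenyl groups it clearly loses ground, with an at least 10-fold higher number from compound 2 to compound 4 (1.01 log units; beyond the scatter) and an at least 4.5-fold higher number from compound 1 to compound 4 (0.66 log units; beyond the scatter). Against pyridin-2-yl there is only a floor, an at least 1.2-fold higher number from compound 3 to compound 4 (0.11 log units; that floor lies within the scatter), so the true size of that step remains unknown.

The compounds shown cannot separate the effect of losing the aromatic ring from that of the ring's nitrogen-bound hydrogen. A morpholine ring or a methylated piperazine at this carbon would test that.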